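Serine amide imines: hydroxyphenyl in place of methoxyphenyl

The source may hold more compounds than are shown below. What is called first, only, known or untested is meant among the compounds shown, and "the series" means these compounds.

Measured so far in a functional assay on cells (Homo sapiens) for cytotoxicity, read by MTT assay, with a stated time of 24 h; a lower number here means a stronger inhibitor, a higher number a weaker inhibitor:
compound 1 `CCCCCCCCCCCCCCNC(=O)[C@H](CO)/N=C/c1ccc(O)cc1` gives 19300 nM;
compound 2 `CCCCCCCCCCCCCCNC(=O)[C@H](CO)NCc1ccccc1OC` gives 100000 nM;
compound 3 `CCCCCCCCCCCCCCNC(=O)[C@H](CO)/N=C/c1ccc(OC)cc1` gives 28100 nM.

Compound 3 holds the second highest of the three numbers in this assay. Its nearest neighbour is compound 1, reached by a 1.5-fold higher number from compound 1 to compound 3 (0.16 log units; within the scatter), so the two do not separate. Its furthest is compound 2, with a 3.6-fold lower number from compound 2 to compound 3 (0.55 log units; beyond the scatter), a modest gap beyond the scatter; compound 1 to compound 2 shows a 5.2-fold higher number from compound 1 to compound 2 (0.71 log units; beyond the scatter).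

The next compound, compound 4 `CCCCCCCCCCCCCCNC(=O)[C@H](CO)/N=C/c1cccc(O)c1`, differs from compound 3 by 3-hydroxyphenyl in place of 4-methoxyphenyl on a carbon with a double bond to nitrogen. Within the data shown here, the only measured step that bears on this change is compound 1 to compound 3, which swapped methyl for hydrogen on the aromatic oxygen and stayed within the scatter. Among the measured compounds shown here, no measured pair moves the oxygen around the ring, so that part of the change is unsupported by any step. The imine linker of compound 1 and compound 3 is kept, so the larger step seen toward compound 2 does not apply.

Compound 4 is therefore expected to land close to compound 3, with a 1.3-fold lower number from compound 3 to compound 4 (0.11 log units; within the scatter) estimated as no step beyond the scatter. The estimate for compound 4 in this assay is 22000 nM, within 9000 nM to 55000 nM.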

Compound 4, half-maximal inhibitory concentration: 32600 nM
The estimate for compound 4 lay 1.5-fold (0.17 log units) below the measured number; the range from low to high includes it.
By their numbers in this assay, from the lowest: compounds 1, 3 and 4 (each within the scatter of the next); then compound 2.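

Moving the oxygen around the ring, with the hydroxyl kept, gives a 1.7-fold higher number from compound 1 to compound 4 (0.23 log units; within the scatter) in this assay, so 3-hydroxyphenyl and 4-hydroxyphenyl do not separate on a carbon with a double bond to nitrogen. The combined change of 3-hydroxyphenyl in place of 4-methoxyphenyl gives a 1.2-fold higher number from compound 3 to compound 4 (0.06 log units; within the scatter), which also stays within the scatter, so compounds 1, 3 and 4 read as one group whichever of these three aryl groups is carried. Compound 2 stays apart from this group, with a 3.1-fold lower number from compound 2 to compound 4 (0.49 log units; beyond the scatter), although that step changes the linker and the aryl group together.

No measurement shown here offers a reason for these results. Still open, on these data alone, is whether an amine or a carboxylic acid on the aromatic ring, or a shorter chain on the amide, would move the number beyond the scatter of this group.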